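This account rests on a few compounds, and the source may have more. Where it says the series, first, only, none or still open, it means among the compounds named here.

Measured so far in a functional assay (mitochondria) for inhibition, with Rattus norvegicus as the target; a lower number here means a stronger inhibitor, a higher number a weaker inhibitor:
- Compound 1 `Cc1cccc(C)c1NC(=O)CN1CCN(CC(O)COc2ccc3oc(-c4ccccc4)nc3c2)CC1`: 23000 nM
- Compound 2 `Cc1nc2cc(OCC(O)CN3CCN(CC(=O)Nc4c(C)cccc4C)CC3(C)C)ccc2s1`: 450 nM

Only these two numbers are available, and a lower number means a stronger inhibitor. Compound 2 gives 450 nM, the lower of the two. Compound 1 gives 23000 nM, and this gap lies well beyond the usual scatter of repeated measurements.

The next compound to be tested is compound 3 `Cc1nc2cc(OC[C@H](O)CN3CCN(CC(=O)Nc4c(C)cccc4C)CC3(C)C)ccc2s1`. Its change from compound 2 is unusually subtle: the two compounds have the same atoms and bonds; at least one stereo element is drawn with a configuration in one of them and without one in the other: 1 of 1 stereo elements differ; a stereocentre at a saturated chain carbon is drawn without a configuration in compound 2 and R in compound 3. The two compounds have the same atoms and bonds, but a stereocentre at a saturated chain carbon is drawn without a configuration in compound 2 and R in compound 3. That is, the spatial arrangement at this one carbon is specified only in compound 3.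

Within the data shown here, no measured pair here shows how much this stereocentre matters in this assay. The natural starting point is therefore compound 2 at 450 nM. The step of a 1.1-fold lower number from compound 2 to compound 3 (0.03 log units; within the scatter) is expected to stay within the scatter, with no firm direction. The estimate for compound 3 is 420 nM, with the result expected between 180 nM and 1000 nM.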

Compound 3, half-maximal inhibitory concentration: 110 nM
Estimate against measurement, compound 3: 3.8-fold (0.58 log units) above; measured number outside the range, below it.
By their numbers in this assay, from the lowest: compound 3; then compound 2; then compound 1.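

The result gives the first measured sign that the spatial arrangement at this saturated chain carbon counts in this assay, since the atoms and bonds stay identical and there is still a 4.1-fold lower number from compound 2 to compound 3 (0.61 log units; beyond the scatter). Compounds 1 and 2 differ in more than one place, so their gap could say nothing about this carbon on its own, whereas here the comparison isolates a single stereocentre. The gap can be tied to this carbon because only one thing separates the two structures: the fact that one of compounds 2 and 3 is drawn with a defined configuration and the other without, at the place where they differ.

The compounds shown leave open how the S arrangement at this carbon would read in this assay, and therefore whether compound 2, drawn without a configuration, holds both arrangements and how much each contributes to its number. Also open, going by these compounds, is whether the R preference would hold once the hydroxyl on the chain is replaced by an amine or a methoxy group, and whether the same preference would appear on the core of compound 1.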